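Swapping tert-butyl on the 1-aminoethyl compound

This account rests on a few compounds, and the source may have more. Where it says the series, first, only, none or still open, it means among the compounds named here.

Measured in a functional assay on HCT-116 cells (Homo sapiens) for inhibition, read by MTT assay, with a stated time of 3 days (on this read-out lower numbers stand for stronger inhibition and higher numbers for weaker inhibition), so far:
Compound 1 `CC(C)(C)c1cc2c(N/N=C/c3nccs3)ncnc2s1` gives 419 nM
Compound 2 `CC(N)c1csc(/C=N/Nc2ncnc3sc(C(C)(C)C)cc23)n1` gives 177 nM

Among the compounds with values here, compound 2 holds the lower of the two numbers in this assay and sits apart from its only neighbour. Within the data shown here, the single measured step of a 2.4-fold lower number from compound 1 to compound 2 (0.37 log units; beyond the scatter) is modest but lies beyond the scatter. It comes from 1-aminoethyl in place of hydrogen on an aromatic carbon.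

Next is compound 3 `CC(N)c1csc(/C=N/Nc2ncnc3sc(C(C)C(C)C)cc23)n1`, which keeps the 1-aminoethyl group and has 1,2-dimethylpropyl in place of tert-butyl on an aromatic carbon, next to the ring sulfur (1,2-dimethylpropyl in place of tert-butyl on an aromatic carbon). Among the measured compounds shown here, no measured pair varies the tert-butyl group, so the data offer no direct precedent and no direction for this change. The step of a 2.4-fold lower number from compound 1 to compound 2 (0.37 log units; beyond the scatter) bears on it only as a rough guide to how far one change has moved this series.

No step beyond the scatter is therefore expected, and the expected change is a 1.1-fold higher number from compound 2 to compound 3 (0.05 log units; within the scatter) as a working figure. For compound 3 the estimated value is 200 nM in this assay, with an expected range from 80 nM to 500 nM for now.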

Compound 3, half-maximal inhibitory concentration in the HCT-116 assay: 315 nM
Compound 3: the middle estimate sits 1.6-fold (0.20 log units) below what was measured, within the range that was stated.
By their numbers in the HCT-116 assay, from the lowest: compounds 2, 3 and 1 (each within the scatter of the next, the first and the last beyond it).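

In the HCT-116 assay the only change shown at this position, on an aromatic carbon next to the ring sulfur, gives a 1.8-fold higher number from compound 2 to compound 3 (0.25 log units; within the scatter) with compound 2 at 177 nM and compound 3 at 315 nM and so leaves compound 3 within the scatter of compound 2 while 1,2-dimethylpropyl stands in place of tert-butyl. In a physicochemical assay, in phosphate buffer, with a stated time of 3 h, at 37 degrees C, at pH 1.2 (a higher number here means that more of the compound is left, a lower number that less of the compound is left), the same swap gives a number 2 percentage points higher from compound 2 to compound 3 (within the scatter) with compound 2 at 81% and compound 3 at 83% and so separates the two groups on neither read-out, which means this position accepts one more carbon in its alkyl group with no change beyond the scatter in either measurement. No measured evidence bears on why the two groups read so alike.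

Whether this tolerance extends beyond these two alkyl groups stays open, as the compounds shown do not tell how a methyl group, a phenyl ring or a carboxylic acid at the same carbon would read in the HCT-116 assay or in the physicochemical assay. Also open, from the compounds shown here alone, is whether 1,2-dimethylpropyl gives a similar result on the core of compound 1, which lacks the 1-aminoethyl group.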